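A few compounds are considered here, and "the series" means these few. Any claim that something is new, unique, unknown or untested is made for them only; others in the source may bear on it.

Measured so far in a functional assay on CHO cells for positive allosteric modulation of muscarinic acetylcholine receptor M5 (Homo sapiens), read by calcium flux; on this read-out higher numbers stand for larger maximal responses and lower numbers for smaller maximal responses:
compound 1 `CCN(Cc1ccccc1C(F)(F)F)C(=O)C1CCN(S(=O)(=O)c2ccc3[nH]ncc3c2)CC1` gives 96%
compound 2 `O=C(C1CCN(S(=O)(=O)c2ccc3[nH]ncc3c2)CC1)N(CCO)Cc1ccccc1C(F)(F)F` gives 60%

Within the data shown here, compound 2 holds the lower of the two numbers; its only neighbour is compound 1, and the single measured step, a number 36 percentage points lower from compound 1 to compound 2 (beyond the scatter), is large and beyond the scatter. Compound 3 `CC(C)(C)CN(Cc1ccccc1C(F)(F)F)C(=O)C1CCN(S(=O)(=O)c2ccc3[nH]ncc3c2)CC1` differs from compound 2 by tert-butyl in place of hydroxymethyl on a saturated chain carbon bound to an amide-type nitrogen. Among the measured compounds shown here, the hydroxy that entered from compound 1 to compound 2 thus leaves again while tert-butyl enters, so only that one step bears here, and it was a number 36 percentage points lower from compound 1 to compound 2 (beyond the scatter). A rise of roughly that size is therefore expected in this assay, a number 30 percentage points higher from compound 2 to compound 3 (beyond the scatter). For compound 3 the expected value is 90%, within 70% to 105%.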

Compound 3, largest response reached (reported as percent of maximum), in percent of the reference or control that the assay uses: 104%
Beside the measured number, compound 3's estimate is 14 percentage points below it; the measured number falls inside the stated range.
By their numbers in this assay, from the lowest: compound 2; then compounds 1 and 3 (each within the scatter of the next).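

In this assay, tert-butyl in place of hydroxymethyl gives a number 44 percentage points higher from compound 2 to compound 3 (beyond the scatter) and so lifts the response well clear of compound 2. Tert-butyl in place of methyl gives a number 8 percentage points higher from compound 1 to compound 3 (within the scatter) and so leaves the response unchanged, which shows that this place accepts neopentyl as well as the shorter chain of compound 1, while among these three compounds only the hydroxy-bearing compound 2 stands apart. Nothing available explains this difference.

On these data alone, whether an amine or a carboxylic acid at this place would track compound 2 remains open. So does the response to a chain longer than neopentyl, or to a hydroxy placed further along such a chain.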